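Swapping Ethyl for Chloro on an Aromatic Ring

This account rests on a few compounds, and the source may have more. Where it says the series, first, only, none or still open, it means among the compounds named here.

In a functional assay on HeLa cells (Homo sapiens) for antiproliferative activity, read by CCK-8 assay, with a stated time of 72 h (on this read-out higher numbers stand for weaker inhibition and lower numbers for stronger inhibition), compound 1 `CCc1ccc(SCc2ccc(C(=O)Nc3ccccc3N)cc2)cc1` gives 3800 nM. Compound 2 `COc1ccc(SCc2ccc(C(=O)Nc3ccccc3N)cc2)cc1OC` gives 3070 nM, so the two numbers lie within the usual scatter of each other. Compound 3 `Nc1ccccc1NC(=O)c1ccc(CSc2ccc(Cl)cc2)cc1` keeps the core of compound 1 but has chloro in place of ethyl on an aromatic carbon, para to a large group: chloro in place of ethyl on an aromatic carbon. Among the measured compounds shown here, no measured pair shows this swap, so the forecast is uncertain. The expected step, a 1.3-fold lower number from compound 1 to compound 3 (0.10 log units; within the scatter), is no larger than the scatter. For compound 3, the estimated value is 3000 nM, with an expected range from 1200 nM to 7500 nM.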

Compound 3, half-maximal inhibitory concentration: 12700 nM
Estimate against measurement, compound 3: 4.2-fold (0.63 log units) below, and the stated range ends below it.
By their numbers in this assay, from the lowest: compounds 2 and 1 (each within the scatter of the next); then compound 3.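

In this assay, the group at this place on the aromatic ring matters: going from 4-ethylphenyl to 4-chlorophenyl gives a 3.3-fold higher number from compound 1 to compound 3 (0.52 log units; beyond the scatter) and so weakens inhibition by a modest step. The two earlier compounds differ in more than one place, so they could not show this single change. No measurement here explains why the step occurs. On these data alone, whether fluoro, an amine, a carboxylic acid or a longer chain such as propyl at this place would give stronger or weaker inhibition remains open. So does whether this swap behaves the same way on another core.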